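Replacing Dichlorophenyl with Dimethoxyphenyl on the Chalcone-like Carbonyl

The source may report more compounds than this note shows. Statements on the series, on what has been measured and on what is new or still open speak of the compounds shown alone.

The series was tested in a functional assay on MCF7 cells (Homo sapiens) for inhibition, read by MTT assay, with a stated time of 48 h; a higher number here means a weaker inhibitor, a lower number a stronger inhibitor. Compound 1 `COc1cc(-c2cc(/C=C3\Cc4ccccc4C3=O)[nH]n2)cc(OC)c1OC` gives 4800 nM in this assay, and compound 2 `COc1ccc2c(c1)C/C(=C\c1cc(-c3cc(OC)c(OC)c(OC)c3)n[nH]1)C2=O` gives 2100 nM; the one step shown between measured compounds, a 2.3-fold lower number from compound 1 to compound 2 (0.36 log units; beyond the scatter), is modest but beyond the scatter. Compound 3 `COc1cc(-c2cc(/C=C/C(=O)c3ccc(Cl)c(Cl)c3)[nH]n2)cc(OC)c1OC` gives 3200 nM, the second highest of the three numbers; its values with compound 1 and with compound 2 both lie within the scatter, so no order among them can be read.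

Compound 4 `COc1ccc(C(=O)/C=C/c2cc(-c3cc(OC)c(OC)c(OC)c3)n[nH]2)cc1OC` differs from compound 3 in one place: 3,4-dimethoxyphenyl in place of 3,4-dichlorophenyl on a carbonyl carbon. Within the data shown here, no measured pair shows this exact exchange. Among the measured compounds shown here, the only step that touches the theme of added methoxy groups is a 2.3-fold lower number from compound 1 to compound 2 (0.36 log units; beyond the scatter), and it is modest. On that slender basis a small lowering of the number is expected, with a real chance of no change beyond the scatter.

Compound 4 is therefore estimated at 2400 nM, within a range from 800 nM to 8000 nM, which as a step means a 1.3-fold lower number from compound 3 to compound 4 (0.12 log units; within the scatter).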

Compound 4, half-maximal inhibitory concentration: 510 nM
Compound 4: the middle estimate sits 4.7-fold (0.67 log units) above what was measured; the whole stated range lies above it.
By their numbers in this assay, from the lowest: compound 4; then compounds 2, 3 and 1 (each within the scatter of the next, the first and the last beyond it).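

In this assay, the group on the carbonyl carbon turns out to be a place where the number responds: 3,4-dimethoxyphenyl in place of 3,4-dichlorophenyl gives a 6.3-fold lower number from compound 3 to compound 4 (0.80 log units; beyond the scatter). Among these compounds, until now the only step beyond the scatter was the added methoxy from compound 1 to compound 2, and compound 3 could not be ordered against either of them, so this is the first sign that this group matters. The entering group carries 2 hydrogen-bond acceptors where the leaving group carries 0, but nothing measured here explains the step. The compounds shown leave open whether both methoxy groups are needed or one alone would give the same step. They also leave open how a phenyl bearing an amine or a carboxylic acid at this place would compare.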